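The source may hold more compounds than are shown below. What is called first, only, known or untested is meant among the compounds shown, and "the series" means these compounds.

Measured so far in a functional assay for agonist activity at G protein-coupled receptor 88 (Homo sapiens), read by HTRF and cAMP accumulation; a lower number here means that less compound is needed, a higher number that more compound is needed for the effect:
compound 1 `CC[C@H](C)[C@H](N)CN(C(=O)[C@@H]1C[C@H]1c1cccc(F)c1)c1ccc(-c2ccccc2)cc1` gives 560 nM
compound 2 `CC[C@H](C)[C@H](N)CN(C(=O)[C@@H]1C[C@H]1c1ccccc1F)c1ccc(-c2ccccc2)cc1` gives 650 nM
compound 3 `CC[C@H](C)[C@H](N)CN(C(=O)[C@@H]1C[C@H]1c1cncnc1)c1ccc(-c2ccccc2)cc1` gives 19000 nM

Compound 3 stands highest of the three numbers in this assay. Its nearest neighbour is compound 2, reached by a 29-fold higher number from compound 2 to compound 3 (1.47 log units; beyond the scatter); the furthest is compound 1, reached by a 34-fold higher number from compound 1 to compound 3 (1.53 log units; beyond the scatter). Both steps are large and beyond the scatter, and both carry the same reading: pyrimidin-5-yl on the saturated ring carbon in place of a fluorophenyl costs a great deal. The two fluorophenyl isomers themselves sit within the scatter of each other, a 1.2-fold higher number from compound 1 to compound 2 (0.06 log units; within the scatter).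

Compound 4 `CC[C@H](C)[C@H](N)CN(C(=O)[C@@H]1C[C@H]1c1nc(C)cs1)c1ccc(-c2ccccc2)cc1` is the next entry. The change from compound 3 is 4-methyl-1,3-thiazol-2-yl in place of pyrimidin-5-yl on a saturated ring carbon. Going by the values given here, no measured step here places one heteroaryl against another heteroaryl on this ring carbon; the only steps that bear on the position are those into compound 3, which show the pyrimidin-5-yl as the weak point of the series. A five-membered ring with one nitrogen and one sulfur is a different kind of heteroaryl, so the expected step in this assay is a 3.8-fold lower number from compound 3 to compound 4 (0.58 log units; beyond the scatter), read as a partial recovery towards the fluorophenyl compounds, with wide uncertainty. Compound 4 is therefore estimated at 5000 nM, in the range 1200 nM to 20000 nM.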

Compound 4, half-maximal effective concentration: 730 nM
Estimate against measurement, compound 4: 6.8-fold (0.84 log units) above; the whole stated range lies above it.
By their numbers in this assay, from the lowest: compounds 1, 2 and 4 (each within the scatter of the next); then compound 3.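

In this assay, the saturated ring carbon of the three-membered ring is not closed to heteroaryl groups: a 26-fold lower number from compound 3 to compound 4 (1.42 log units; beyond the scatter), so the loss seen earlier belongs to the pyrimidin-5-yl and not to heteroaryl groups in general among the compounds shown. The 4-methyl-1,3-thiazol-2-yl cannot be told apart from either fluorophenyl group, with a 1.1-fold higher number from compound 2 to compound 4 (0.05 log units; within the scatter) and a 1.3-fold higher number from compound 1 to compound 4 (0.12 log units; within the scatter), so a fluorine-bearing benzene ring is not needed at this position for the activity seen in compound 1 and compound 2. The entering and leaving groups match in heavy atoms, hydrogen-bond donors and hydrogen-bond acceptors, yet they lie far apart in this read-out, and no measurement at hand accounts for that gap.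

The compounds shown leave open whether the recovery rests on the 4-methyl group or on the five-membered ring, a question that the unsubstituted 1,3-thiazol-2-yl would address, while pyridin-3-yl would test how much of the loss follows from the second ring nitrogen of the pyrimidin-5-yl. Also open, as far as these compounds go, is how this position responds to an amine, a carboxylic acid or a longer alkyl chain on the heteroaryl ring.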